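Replacing 4-(dimethylamino)phenyl with naphthalen-1-yl in compound 2

This account rests on a few compounds, and the source may have more. Where it says the series, first, only, none or still open, it means among the compounds named here.

Measured in a functional assay on MCF7 cells (Homo sapiens) for antiproliferative activity, read by MTT assay, with stated times of 24 h and 72 h; on this read-out higher numbers stand for weaker inhibition and lower numbers for stronger inhibition:
- compound 1 `COc1ccc([C@@H]2[C@H](Oc3ccccc3)C(=O)N2c2cc(OC)c(OC)c(OC)c2)cc1`: 35000 nM
- compound 2 `COc1cc(N2C(=O)[C@@H](Oc3ccccc3)[C@H]2c2ccc(N(C)C)cc2)cc(OC)c1OC`: 31000 nM

With only these two measurements, compound 2 stands level with compound 1, since the two values lie within the scatter of each other. Compound 3 `COc1cc(N2C(=O)[C@@H](Oc3ccccc3)[C@H]2c2cccc3ccccc23)cc(OC)c1OC` keeps the shared core but changes one group: naphthalen-1-yl in place of 4-(dimethylamino)phenyl on a saturated ring carbon. Naphthalen-1-yl takes the place of 4-(dimethylamino)phenyl on a saturated ring carbon. Among the compounds with values here, the only measured step that bears on this is a 1.1-fold lower number from compound 1 to compound 2 (0.05 log units; within the scatter), where dimethylamino replaced methoxy on an aromatic carbon. Within the data shown here, that step is small, but it exchanged only one group on the aromatic ring, whereas the new change replaces the whole 4-(dimethylamino)phenyl group, so it is a thin guide. The data favour no direction, so no shift beyond the scatter is expected in this assay. The estimated size of the change is a 1.0-fold lower number from compound 2 to compound 3 (0.01 log units; within the scatter). For compound 3 the expected value is 30000 nM, with an estimated range of 10000 nM to 80000 nM.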

Compound 3, half-maximal inhibitory concentration: 53000 nM
Compound 3: the middle estimate sits 1.8-fold (0.25 log units) below what was measured; the measured number falls inside the stated range.
By their numbers in this assay, from the lowest: compounds 2, 1 and 3 (each within the scatter of the next).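

In this assay the new steps read a 1.7-fold higher number from compound 2 to compound 3 (0.23 log units; within the scatter) and a 1.5-fold higher number from compound 1 to compound 3 (0.18 log units; within the scatter) when naphthalen-1-yl takes the place of 4-(dimethylamino)phenyl or of 4-methoxyphenyl on this saturated ring carbon. Within the data shown here, the earlier step changed only one group on the aromatic ring, whereas these replace the whole group, going from one six-membered aromatic ring to two and losing the hydrogen-bond acceptor of the dimethylamino group, and still neither step lies beyond the scatter. No measurement is available that ties these numbers to any property of the groups.

The compounds shown leave open whether a group with no aromatic ring on this carbon, such as cyclohexyl, would shift the number beyond the scatter. The same question stands for a phenyl ring carrying a carboxylic acid.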